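The compounds below may be only part of what the source reports. "The series", "measured", "known", "first", "only" and "open" are said of these compounds alone.

Values so far in an ADME assay on Vero cells (Chlorocebus sabaeus) for cytotoxicity, read by fluorescence, with a stated time of 4 days; a higher number here means a weaker inhibitor, a lower number a stronger inhibitor
- compound 1 `CC(C)(CNC(=O)c1ccc2ccccc2c1)CC1=C(O)C(=O)c2ccccc2C1=O` gives 46700 nM
- compound 2 `CC(C)(CNC(=O)c1ccc2ccccc2c1O)CC1=C(O)C(=O)c2ccccc2C1=O` gives 93700 nM
- compound 3 `COC1=C(CC(C)(C)CNC(=O)c2ccc3ccccc3c2)C(=O)c2ccccc2C1=O` gives 36000 nM

Compound 1 sits within the scatter of both other compounds. The two measured steps are a 2.0-fold higher number from compound 1 to compound 2 (0.30 log units; within the scatter) and a 1.3-fold lower number from compound 1 to compound 3 (0.11 log units; within the scatter).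

Compound 4 `COc1ccccc1C(=O)NCC(C)(C)CC1=C(O)C(=O)c2ccccc2C1=O` has not yet been measured in this assay. It differs from compound 1 by 2-methoxyphenyl in place of naphthalen-2-yl on a carbonyl carbon. Neither measured step makes this replacement. The hydroxy step to compound 2 is the nearer guide, as a change on an aromatic carbon, while the methyl step to compound 3 is a change on an oxygen and of another kind. On these data alone, neither step leaves the scatter, so the data give no sign of a large move, although replacing a whole group remains untested in this set. Among the measured compounds shown here, with compound 2 at 93700 nM as the only aromatic change to go on, a small move towards a higher number is expected, and none beyond the scatter.

The expected size is a 1.3-fold higher number from compound 1 to compound 4 (0.11 log units; within the scatter).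

For compound 4 the estimate is 60000 nM, with an estimated range from 25000 nM to 130000 nM.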

Compound 4, half-maximal inhibitory concentration: 31200 nM
Estimate against measurement, compound 4: 1.9-fold (0.28 log units) above; measured number inside the range.
By their numbers in this assay, from the lowest: compounds 4, 3, 1 and 2 (each within the scatter of the next, the first and the last beyond it).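

In this assay, the exchange of naphthalen-2-yl for 2-methoxyphenyl on a carbonyl carbon gives a 1.5-fold lower number from compound 1 to compound 4 (0.18 log units; within the scatter). Where the earlier steps touched only a single hydroxy or methyl group, this one replaces the whole aromatic group on the amide carbonyl, going from two six-membered aromatic rings of carbon only to one and adding one hydrogen-bond acceptor, and the number still stays within the scatter, so in this pair the read-out does not respond to the size of the group at this position. No measured evidence on these compounds accounts for this result.

On these data alone, what remains open is how the two parts of the change separate: a plain phenyl on the same carbonyl carbon would distinguish the loss of the second ring from the entry of the methoxy group. Among the compounds shown here, it is also open whether a group of another kind there, such as a cyclohexyl ring, a basic amine or a carboxylic acid, would carry the number beyond the scatter, which no step has yet done from compound 1.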